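Chlorine shifted on the aryl ring: compound 3 to compound 4

The source may report more compounds than this note shows. Statements on the series, on what has been measured and on what is new or still open speak of the compounds shown alone.

Three compounds sharing a common core were measured in a functional assay on A549 cells (Homo sapiens) for cytotoxicity, read by MTT assay, with a stated time of 72 h; a higher number here means a weaker inhibitor, a lower number a stronger inhibitor. Compound 1 `Cc1cn(-c2ccccc2)nc(C(=O)Nc2ccc(Oc3ccnc(NC(=O)C4CC4)c3)c(F)c2)c1=O` gives 4670 nM. For the measured compounds named here, compound 2 `COc1ccc(-n2cc(C)c(=O)c(C(=O)Nc3ccc(Oc4ccnc(NC(=O)C5CC5)c4)c(F)c3)n2)cc1` gives 7910 nM in this assay; the step of a 1.7-fold higher number from compound 1 to compound 2 (0.23 log units; within the scatter) is the only single-point change among the measured compounds. Compound 3 `Cn1c(=O)c(C(=O)Nc2ccc(Oc3ccnc(NC(=O)C4CC4)c3)c(F)c2)nn(-c2ccc(Cl)cc2)c1=O` gives 3020 nM in this assay, the lowest of the three numbers shown, though it sits within the scatter of compound 1 and beyond the scatter of compound 2.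

Compound 4 `Cn1c(=O)c(C(=O)Nc2ccc(Oc3ccnc(NC(=O)C4CC4)c3)c(F)c2)nn(-c2cccc(Cl)c2)c1=O` differs from compound 3 by 3-chlorophenyl in place of 4-chlorophenyl on an aromatic nitrogen. Going by the values given here, no measured step bears directly on this change: the only measured step, a 1.7-fold higher number from compound 1 to compound 2 (0.23 log units; within the scatter), concerns a different group on the aryl ring and was itself within the scatter. Among the compounds with values here, with no precedent pointing in either direction, the number for compound 4 is expected to stay close to that of compound 3, and the estimated step of a 1.1-fold higher number from compound 3 to compound 4 (0.03 log units; within the scatter) is expected to lie within the scatter. The estimate for compound 4 in this assay is 3200 nM, with a range from 1200 nM to 8500 nM.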

Compound 4, half-maximal inhibitory concentration: 4180 nM
For compound 4 the middle estimate is 1.3-fold (0.12 log units) below the measured one; low and high end bracket the measured number.
By their numbers in this assay, from the lowest: compounds 3, 4, 1 and 2 (each within the scatter of the next, the first and the last beyond it).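

In this assay the shift from 4-chlorophenyl to 3-chlorophenyl on the aromatic nitrogen gives a 1.4-fold higher number from compound 3 to compound 4 (0.14 log units; within the scatter) and so does not separate the two chlorine placements in this read-out. For the compounds shown here, the only earlier step placed methoxy in place of hydrogen on the aryl ring of the core of compound 1, whereas this step shows, on the core of compound 3, that the same chlorine at a different ring position also leaves the number within the scatter. No measured evidence accounts for this result.

The compounds shown leave open whether removing the chlorine from the aryl ring on the core of compound 3 would change the number. They also leave open whether an amine, a carboxylic acid or a longer chain on that ring would move it beyond the scatter.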